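A few compounds are considered here, and "the series" means these few. Any claim that something is new, unique, unknown or untested is made for them only; others in the source may bear on it.

Measured in a functional assay on the whole organism (Hindlimb, strain albino) with Mus musculus as the target, in the maximal electroshock model, with a stated time of 0.5 h; a higher number here means that more compound is needed for the effect, a lower number that less compound is needed:
- compound 1 `COc1ccc(C2CC(Nc3nc4ccc(Cl)cc4s3)=NN2C(C)=O)cc1O`: 127 umol/kg
- compound 2 `CC(=O)N1N=C(Nc2nc3ccc(Cl)cc3s2)CC1c1ccc(Cl)cc1`: 79.5 umol/kg

Going by the values given here, compound 2 stands level with the only other measured compound: a 1.6-fold lower number from compound 1 to compound 2 (0.20 log units; within the scatter). Among the compounds with values here, that step, 4-chlorophenyl in place of 3-hydroxy-4-methoxyphenyl on a saturated ring carbon, is the only guide to compound 3 `CC(=O)N1N=C(Nc2nc3ccc(Cl)cc3s2)CC1OC1=CC=C1`, which changes the same place: a group of 5 heavy atoms (4 carbon, 1 oxygen; one four-membered non-aromatic ring of carbon only) in place of a group of 7 heavy atoms (6 carbon, 1 chlorine; one six-membered aromatic ring of carbon only), on a saturated ring carbon. The entering group resembles neither earlier group, so one step within the scatter gives weak support and no direction. In this assay, no step beyond the scatter is expected, and the estimated step is a 1.3-fold higher number from compound 2 to compound 3 (0.10 log units; within the scatter). Compound 3 is estimated at 100 umol/kg, with an expected range of 40 umol/kg to 250 umol/kg.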

Compound 3, dose for half-maximal effect: 212 umol/kg
Estimate against measurement, compound 3: 2.1-fold (0.33 log units) below; measured number inside the range.
By their numbers in this assay, from the lowest: compounds 2, 1 and 3 (each within the scatter of the next, the first and the last beyond it).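

In this assay, the saturated ring carbon now gives a step beyond the scatter (a 2.7-fold higher number from compound 2 to compound 3 (0.43 log units; beyond the scatter)), which the first pair did not. Against 3-hydroxy-4-methoxyphenyl, the same entering group stays within the scatter (a 1.7-fold higher number from compound 1 to compound 3 (0.22 log units; within the scatter)), so the separation holds only against 4-chlorophenyl. Nothing available accounts for this step.

The oxygen and the four-membered ring enter together in compound 3, so their shares cannot be separated. From the compounds shown here alone, a phenoxy group, an amine or a carboxylic acid on this carbon remains open.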